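The source may hold more compounds than are shown below. What is called first, only, known or untested is meant among the compounds shown, and "the series" means these compounds.

Of the compounds shown here, two sharing one core have been tested in a functional assay on A2780 cells (Homo sapiens) for inhibition; a lower number here means a stronger inhibitor, a higher number a weaker inhibitor. Compound 1 `Cc1cc(/C=C/COC2CCOCC2)cc(=O)o1` gives 2100 nM, and compound 2 `CCCC#Cc1cc(C)oc(=O)c1` gives 4800 nM, the higher of the two numbers, so compound 2 is the weaker inhibitor of the pair by a gap beyond the usual scatter. Compound 3 `CCCCC#Cc1cc(C)oc(=O)c1` differs from compound 2 in one place: methyl in place of hydrogen on a saturated chain carbon, three bonds along the chain from a triple-bonded carbon. For the measured compounds named here, no measured pair shows what this change does, so the expectation rests on the change alone, which adds little. The estimated step, a 1.3-fold lower number from compound 2 to compound 3 (0.10 log units; within the scatter), stays within the scatter. For compound 3 the expected value is 3800 nM, ranging from 1500 nM to 9000 nM.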

Compound 3, half-maximal inhibitory concentration: 7000 nM
Beside the measured number, compound 3's estimate is 1.8-fold (0.27 log units) below it; measured number inside the range.
By their numbers in this assay, from the lowest: compound 1; then compounds 2 and 3 (each within the scatter of the next).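

In this assay the methyl in place of hydrogen, on a saturated chain carbon, three bonds along the chain from a triple-bonded carbon, gives a 1.5-fold higher number from compound 2 to compound 3 (0.16 log units; within the scatter) as its step. This change, which can also be read as propyl to butyl, therefore leaves the two compounds indistinguishable in this read-out. No available evidence bears on why this is so.

As far as these compounds go, whether a longer chain would shift the number beyond the scatter remains open. So does the effect of an amine or a carboxylic acid at the chain's end.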